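The source may hold more compounds than are shown below. What is called first, only, known or untested is meant among the compounds shown, and "the series" means these compounds.

Measured so far in an ADME assay on A549 cells (Homo sapiens) for cytotoxicity, read by LDH release, with a stated time of 15 h; a higher number here means that more compound is tolerated, a lower number that less compound is tolerated:
- compound 1 `CC1(Nc2ccc(NC(=O)c3cc(Cl)ccc3O)c(Cl)c2)CCCCC1`: 86500 nM
- compound 2 `O=C(Nc1ccc(NCc2ccc(F)cc2)cc1Cl)c1cc(Cl)ccc1O`: "not determined" (no result reported)
- compound 3 `O=C(Nc1ccc(NCC2CCNCC2)cc1Cl)c1cc(Cl)ccc1O`: "not determined" (no result reported)

Only compound 1 carries a number, and compound 1 stands at 86500 nM. Compound 3 has no position on this scale: the entry for compound 3 reads "not determined" (no result reported). The entry for compound 2 is the same, "not determined" (no result reported), so compound 3 cannot be ranked against either neighbour.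

The next compound is compound 4 `CCCNc1ccc(NC(=O)c2cc(Cl)ccc2O)c(Cl)c1`, still unmeasured in this assay. The structural change is ethyl in place of piperidin-4-yl on a saturated chain carbon bound to a nitrogen on an aromatic ring. Put plainly, piperidin-4-yl leaves and ethyl enters. Cut one bond further out, the same difference reads (piperidin-4-yl)methyl to propyl.

Among the compounds with values here, the series offers no step between measured compounds, and the change has no measured precedent. Within the data shown here, no step from compound 3 can be calculated either. The working expectation is therefore no shift beyond the usual scatter from the one available anchor, compound 1 at 86500 nM, with a slight lean towards less compound tolerated. For compound 4 the expected value is 60000 nM, with an estimated range of 20000 nM to 130000 nM.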

Compound 4, half-maximal cytotoxic concentration: 69700 nM
Compound 4: middle estimate off by 1.2-fold (0.07 log units), on the low side; the range from low to high includes it.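

With compound 4, the series gains its first readable step in this assay, with propyl in place of 1-methylcyclohexyl on a nitrogen on an aromatic ring giving a 1.2-fold lower number from compound 1 to compound 4 (0.09 log units; within the scatter) as the result. On the shared core, an open chain and a substituent carrying a saturated ring are therefore not told apart by this assay at this nitrogen, a reading that rests on this single pair. Steps involving compound 2 or compound 3 cannot be read, so the exchange of piperidin-4-yl for ethyl on the saturated chain carbon has no size here. No available data offer an explanation for this result.

Going by these compounds, two numbers on one core fix no trend, and it remains open whether a longer chain such as hexyl would stay within the scatter of compound 4. Also open, on these data alone, is how a carboxylic acid at the end of the propyl chain would read in this assay, and whether an amine there would match compound 4.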